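The source may report more compounds than this note shows. Statements on the series, on what has been measured and on what is new or still open speak of the compounds shown alone.

Of the compounds shown here, three built on a shared core have been measured in a functional assay on SiHa cells (Homo sapiens) for antiproliferative activity, read by CCK-8 assay, with a stated time of 72 h; a lower number here means a stronger inhibitor, a higher number a weaker inhibitor. Compound 1 `CCOC(=O)Oc1cc(-c2cncnc2-c2cc(OC)c(OC)c(OC)c2)ccc1OC` gives 1890 nM, compound 2 `COc1ccc(-c2cncnc2-c2cc(OC)c(OC)c(OC)c2)cc1Cl` gives 1330 nM, and compound 3 `CCSc1ccc(-c2cncnc2-c2cc(OC)c(OC)c(OC)c2)cc1` gives 1030 nM. Compound 3 has the lowest number of the three, but all three values lie within the scatter of one another.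

Compound 4 `COc1cc(-c2ncncc2-c2ccc(C(N)=O)cc2)cc(OC)c1OC` carries carbamoyl in place of ethylsulfanyl on an aromatic carbon. Among the measured compounds shown here, two measured steps bear on this change. The closer one is a 1.3-fold lower number from compound 2 to compound 3 (0.11 log units; within the scatter), which exchanges one substituted phenyl group for another. The other is a 1.4-fold lower number from compound 1 to compound 2 (0.15 log units; within the scatter). Both are small, so this group has so far moved this assay very little. However, no measured compound has a hydrogen-bond donor in this group, so these steps are only a loose guide, and a wide range is needed.

A modest move to a higher number is expected, estimated as a 2.4-fold higher number from compound 3 to compound 4 (0.39 log units; beyond the scatter). For compound 4 the estimated value is 2500 nM, with an expected range of 800 nM to 9000 nM.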

Compound 4, half-maximal inhibitory concentration: > 100000 nM
Compound 4: a limit, no number; the forecaster's own chance of this, stated with the estimate: 10%; middle value at least 40-fold (1.60 log units) from the limit.
By their numbers in this assay, from the lowest: compounds 3, 2 and 1 (each within the scatter of the next). At a limit, above all of these: compound 4.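

The earlier steps shown here were all within the scatter and gave the impression that this part of the molecule barely moved this assay, yet carbamoyl in place of ethylsulfanyl gives an at least 97-fold higher number from compound 3 to compound 4 (1.98 log units; beyond the scatter). Measured against a different neighbour, 4-carbamoylphenyl in place of 3-chloro-4-methoxyphenyl gives an at least 75-fold higher number from compound 2 to compound 4 (1.87 log units; beyond the scatter), so this position is far from indifferent to what it carries, even when the entering and leaving groups have the same heavy-atom count. The value of compound 4 is a limit of the assay and not a number, so the full size of both steps stays unknown: the limit of > 100000 nM in this assay, at which 1 of the 4 values shown sits.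

Carbamoyl differs from ethylsulfanyl in more than one way, as it brings a hydrogen-bond donor and a double bond, and the compounds shown do not separate these. A nitrile, a methyl ester or a carboxylic acid at this place would be needed to tell how far the result extends beyond carbamoyl itself.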